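A few compounds are considered here, and "the series" means these few. Any claim that something is new, unique, unknown or untested is made for them only; others in the source may bear on it.

Compound 1, `C=C1C[C@@H](O)/C=C(\C)CC[C@@H](C(C)C)[C@@H](O)[C@@H]1O`. In an ADME assay on cells (Macrophage, Mus musculus) for cytotoxicity, read by MTT assay, with a stated time of 24 h (a lower number here means a stronger inhibitor, a higher number a weaker inhibitor), compound 1 gives >= 10 ug/mL, which is a limit of the assay and not a number.
Compound 2, `C=C1C[C@@H](OC(C)=O)/C=C(\C)CC[C@@H](C(C)C)[C@@H](O)[C@@H]1O`. In this assay compound 2 gives >= 10 ug/mL, again only a limit.
Compound 3, `C/C1=C\[C@H](O)C[C@]2(C)O[C@H]2[C@H](O)[C@H](C(C)C)CC1`. In this assay compound 3 gives >= 10 ug/mL, also a limit rather than a number.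

Compound 4, `CC(=O)O[C@H]1/C=C(\C)CC[C@@H](C(C)C)[C@@H](O)[C@@H]2O[C@@]2(C)C1`, has not yet been measured in this assay. It is derived from compound 3 by a single change: acetyl in place of hydrogen on an oxygen on a saturated carbon. The same change has already been made once among the measured compounds, from compound 1 to compound 2: acetyl in place of hydrogen on an oxygen on a saturated carbon. Its size there is a step that the two limits leave unreadable from compound 1 to compound 2, since both ends of that pair sit at a limit. Compound 3 and compound 1 share their atoms but have them joined differently; the difference between the two cores is not broken down here. The two place descriptions are the same word for word, so the change from compound 3 to compound 4 is the same change as that from compound 1 to compound 2.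

Within the data shown here, the expectation for compound 4 rests on (the limit of >= 10 ug/mL in this assay, at which 3 of the 3 values shown sit), which leaves no measured step of readable size anywhere in this small set. The step from compound 3 to compound 4 is therefore estimated as a step that the limit leaves unreadable from compound 3 to compound 4. Compound 4 is expected to give about 15 ug/mL in this assay, most likely reported again as a limit, with a plausible range of 7 ug/mL to 40 ug/mL.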

Compound 4, half-maximal inhibitory concentration: >= 10 ug/mL
Compound 4: a limit, no number; the forecaster's own chance of this, stated with the estimate: 80%; the middle value is on the limit's open side.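

In this assay compound 4 gives >= 10 ug/mL, which is a limit and not a number. Compound 3 also sits at a limit, so the step from compound 3 to compound 4 cannot be read, just as the step from compound 1 to compound 2 cannot, and all the compounds share one result: the limit of >= 10 ug/mL in this assay, at which 4 of the 4 values shown sit. The compounds shown leave open what actual value any of them has in this assay and whether the change from hydroxy to acetoxy alters it.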